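A few compounds are considered here, and "the series" means these few. Any claim that something is new, unique, unknown or untested is made for them only; others in the source may bear on it.

Working notes on the series. Going by the values given here, in a functional assay on MOLT-4 cells (Homo sapiens) for cytotoxicity, read by CCK-8 assay, with a stated time of 24 h (a lower number here means a stronger inhibitor, a higher number a weaker inhibitor), compound 1 `C=CC(=O)N1C(=O)CC(c2ccc(OC)cc2)Sc2ccccc21` gives 83200 nM and compound 2 `C=CC(=O)N1C(=O)CC(c2cccc(Cl)c2)Sc2ccccc21` gives 77500 nM, so compound 1 stands level with the only other measured compound, the two values lying within the scatter of each other.

Compound 3 `C=CC(=O)N1C(=O)CC(c2ccc(C(=O)OC)cc2)Sc2ccccc21` has not yet been measured. It differs from compound 1 by methoxycarbonyl in place of methoxy on an aromatic carbon, para to a large group.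

Among the compounds with values here, one measured step bears on this change: a 1.1-fold lower number from compound 1 to compound 2 (0.03 log units; within the scatter), with 3-chlorophenyl in place of 4-methoxyphenyl on a saturated ring carbon. That single step is a thin basis, and no direction can be drawn from it. No shift beyond the scatter is therefore expected in this assay.

The expected step is a 1.0-fold lower number from compound 1 to compound 3 (0.02 log units; within the scatter). For compound 3 the estimated value is 80000 nM, with an expected range of 38000 nM to 160000 nM.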

Compound 3, half-maximal inhibitory concentration: 79600 nM
Compound 3: middle estimate off by 1.0-fold (0.00 log units), on the high side, and the stated range covers the measured number.
By their numbers in this assay, from the lowest: compounds 2, 3 and 1 (each within the scatter of the next).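

In this assay the replacement of methoxy by methoxycarbonyl gives a 1.0-fold lower number from compound 1 to compound 3 (0.02 log units; within the scatter) on an aromatic carbon, para to a large group. Compared with the earlier step, which exchanged the whole 4-methoxyphenyl for 3-chlorophenyl, this change keeps the ring and the place of substitution fixed and alters only the group, and the entering group has more heavy atoms and more hydrogen-bond acceptors than the one it replaces, yet the step stays within the scatter. Nothing available accounts for this result.

As far as these compounds go, whether an amine or a carboxylic acid on this aromatic carbon would also stay within the scatter remains open. So does the effect of a longer chain on the ester, and whether any change at this place moves the number beyond the scatter.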